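The compounds below may be only part of what the source reports. "The series", "measured", "known", "first", "only" and "open" are said of these compounds alone.

Series notes, RD cell growth series.

Compound 1 `CN1C(=O)N(C)C2C1NC(=S)N2/N=C/C=C/c1ccccc1` is the reference with the dimethyl core and the unsubstituted phenyl end. In a functional assay on RD cells (Homo sapiens) for inhibition, read by MTT assay, with a stated time of 72 h (on this read-out higher numbers stand for weaker inhibition and lower numbers for stronger inhibition), compound 1 gives 46000 nM. Compound 2 `CN1C(=O)N(C)C2C1NC(=S)N2/N=C/C=C/c1ccccc1[N+](=O)[O-]` carries the same core and differs only by nitro in place of hydrogen on an aromatic carbon; in this assay compound 2 gives 32400 nM. The step of a 1.4-fold lower number from compound 1 to compound 2 (0.15 log units; within the scatter) is therefore small and lies inside the scatter of repeated runs, so nothing can be said about an order between compound 1 and compound 2.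

Compound 3 `CCN1C(=O)N(CC)C2C1N=C(SC)N2/N=C/C=C/c1ccccc1` has the diethyl core with the methylthio group in place of the thione; the difference between the two cores is not broken down here. In this assay compound 3 gives 24000 nM. Its number is within the scatter of both compound 2 and compound 1, so no ranking among the three is supported.

Compound 4 `CCN1C(=O)N(CC)C2C1N=C(SC)N2/N=C/C=C/c1ccccc1[N+](=O)[O-]` is the not yet measured partner of compound 3 and differs from it by nitro in place of hydrogen on an aromatic carbon. Within the data shown here, this is the same kind of change as the one from compound 1 to compound 2, made on the other core. The expectation for compound 4 rests only on compound 3 at 24000 nM and on the step of a 1.4-fold lower number from compound 1 to compound 2 (0.15 log units; within the scatter), with the added uncertainty of a change of core. The step of a 1.4-fold lower number from compound 3 to compound 4 (0.15 log units; within the scatter) is expected to be of similar small size. For compound 4 in this assay an estimate of 17000 nM is set, with an expected range from 8000 nM to 40000 nM.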

Compound 4, half-maximal inhibitory concentration: 41900 nM
Beside the measured number, compound 4's estimate is 2.5-fold (0.39 log units) below it; the measured number lies above the stated range.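

In this assay, nitro in place of hydrogen on an aromatic carbon, read on the core of compound 3 as phenyl to 2-nitrophenyl, gives a 1.7-fold higher number from compound 3 to compound 4 (0.24 log units; within the scatter), so this pair supports no order. Set beside the earlier pair on the dimethyl core, the two steps are not told apart: the same change on two cores in this assay, a 1.4-fold lower number (0.15 log units; within the scatter) from compound 1 to compound 2 and a 1.7-fold higher number (0.24 log units; within the scatter) from compound 3 to compound 4, 2.5-fold (0.39 log units) apart, within the scatter of two such steps. Among these compounds, this shows only that the change stayed inside the scatter on both cores, so that no core-dependent behaviour can be read from these two pairs; it does not show that the change is without effect, nor that a step of fixed size carries from one core to another.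

The compounds shown leave open how other groups in place of nitro on the phenyl end, such as an amine or a carboxylic acid, would read in this assay. Also open, going by these compounds, is what each part of the core difference contributes alone, the ethyl groups against the methyl groups and the methylthio group against the thione, and whether a longer chain in place of ethyl would move the numbers beyond the scatter.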